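The compounds below may be only part of what the source reports. "The series", "measured", "known", "first", "only" and "open" are said of these compounds alone.

Compound 1 `COc1cc(-n2c(-c3ccc(O)cc3)c[nH]c2=O)cc(OC)c1OC` gives > 50000 nM as its result
Compound 2 `COc1ccc(-c2c[nH]c(=O)n2-c2cc(OC)c(OC)c(OC)c2)cc1[N+](=O)[O-]` gives "not determined" (no result reported) as its result

Both compounds were put through a functional assay on MCF7 cells (Homo sapiens) for cytotoxicity, read by MTT assay, with a stated time of 48 h (on this read-out higher numbers stand for weaker inhibition and lower numbers for stronger inhibition), as their test of cell killing. In this assay compound 1 gives > 50000 nM as its entry, and this is a limit of the assay, not a number. For compound 2 the entry reads "not determined" (no result reported) so it has no position of its own on the scale. The only other entry is the limit, as the limit of > 50000 nM in this assay, at which 1 of the 2 values shown sits, shows for this small set.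

Compound 3 `COc1ccc(-c2c[nH]c(=O)n2-c2cc(OC)c(OC)c(OC)c2)cc1N` has not yet been measured. It differs from compound 2 by a single change, amino in place of nitro on an aromatic carbon with amino in place of nitro on an aromatic carbon, ortho to a methoxy group.

Among the measured compounds shown here, no measured step gives a size for this change, so any expectation here is loose. A large step toward stronger inhibition in this assay is expected, measured against the limit of compound 1, though compound 3 could still land at that limit. Compound 3 is estimated at 3000 nM in this assay with an expected range from 100 nM to 50000 nM as its likely span.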

Compound 3, half-maximal inhibitory concentration: > 50000 nM
Compound 3 ended at the assay's limit; the forecaster's own chance of this, stated with the estimate: 35%; middle value at least 16-fold (1.22 log units) from the limit.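

In this assay compound 3 gives > 50000 nM, a limit of the assay and not a number. Among the compounds shown here, compound 1 stands at that same limit and compound 2 has no number, and no step from compound 3 to either of them can be read. Still open, as far as these compounds go, are what amino in place of nitro does in these cells and how compound 1 and compound 3 truly compare.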